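Series notes: cytotoxicity and the step to compound 4

This account rests on a few compounds, and the source may have more. Where it says the series, first, only, none or still open, it means among the compounds named here.

Measured so far in a toxicity assay on Vero cells (Chlorocebus sabaeus) for cytotoxicity; on this read-out higher numbers stand for lower toxicity in this test and lower numbers for higher toxicity in this test:
compound 1, `Cc1ccc(C(=O)/C=C/c2ccc([N+](=O)[O-])o2)cc1`, gives 439000 nM
compound 2, `O=C(/C=C/c1ccc([N+](=O)[O-])o1)c1ccc(Br)cc1`, gives 354000 nM
compound 3, `O=C(/C=C/c1ccc([N+](=O)[O-])o1)c1ccc(OCc2ccccc2)cc1`, gives 515000 nM

Compound 3 holds the highest of the three numbers in this assay, but its separation from the others is small: a 1.2-fold higher number from compound 1 to compound 3 (0.07 log units; within the scatter) and a 1.5-fold higher number from compound 2 to compound 3 (0.16 log units; within the scatter), so no ranking among the three is supported.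

Compound 4, `COc1ccc(COc2ccc(C(=O)/C=C/c3ccc([N+](=O)[O-])o3)cc2)cc1`, differs from compound 3 by methoxy in place of hydrogen on an aromatic carbon. Among the measured compounds shown here, no measured step places a methoxy at this site; the three steps that exist all exchange the group on the other aromatic ring of the shared core, and each stayed within the scatter: a 1.2-fold lower number from compound 1 to compound 2 (0.09 log units; within the scatter), a 1.2-fold higher number from compound 1 to compound 3 (0.07 log units; within the scatter), a 1.5-fold higher number from compound 2 to compound 3 (0.16 log units; within the scatter). Since even these broader exchanges left this assay unchanged beyond the scatter, a smaller addition on the benzyl side is expected to do likewise.

For compound 4 the expected step is a 1.0-fold lower number from compound 3 to compound 4 (0.01 log units; within the scatter), giving an estimate of 500000 nM in this assay, within 250000 nM to 1000000 nM.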

Compound 4, half-maximal cytotoxic concentration: 311000 nM
Compound 4: the middle estimate sits 1.6-fold (0.21 log units) above what was measured, within the range that was stated.
By their numbers in this assay, from the lowest: compounds 4, 2, 1 and 3 (each within the scatter of the next).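

Working notes: this is the first change on the benzyl side of compound 3 rather than at the group on the other aromatic ring of the shared core. In this assay, benzyl to 4-methoxybenzyl gives a 1.7-fold lower number from compound 3 to compound 4 (0.22 log units; within the scatter), so adding a methoxy on this aromatic carbon, para to a large group, does not separate the two compounds in this test. No measured evidence bears on this result, and the two values alone offer no explanation.

Still open, going by these compounds, is whether an amine, a carboxylic acid or a longer alkoxy chain in place of the methoxy would also stay within the scatter in this assay. One methoxy step also cannot show how the read-out responds when the nitro group on the shared core is exchanged for a nitrile.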